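The source may report more compounds than this note shows. Statements on the series, on what has been measured and on what is new or still open speak of the compounds shown alone.

Compound 1 `COc1ccc(C(=O)c2ccc(OC)c3c2OC(C)(C)C=C3)c(NC(=O)CBr)c1`: 3250 nM
Compound 2 `COc1ccc(C(=O)c2ccc(OC)c3c2C=CC(C)(C)O3)c(NC(=O)CO)c1`: 630 nM
Compound 3 `COc1ccc(C(=O)c2cc(OC)c(OC)c(OC)c2)c(NC(=O)CO)c1`: 120 nM

All three numbers come from a functional assay on HCT-8 cells (Homo sapiens) for antiproliferative activity, read by MTT assay, with a stated time of 48 h; a higher number here means a weaker inhibitor, a lower number a stronger inhibitor. Compound 3 has the lowest number of the set, which makes it the strongest inhibitor measured so far. Its gaps to compound 2 and to compound 1 both lie beyond the usual scatter of repeated measurements. Going by the values given here, these three compounds differ from one another in more than one place, so no measured pair isolates the effect of a single change.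

The next compound, compound 4 `COc1ccc(C(=O)c2cc(OC)c(OC)c(OC)c2)c(NC(=O)CN)c1`, keeps everything in compound 3 except one group. The change is amino in place of hydroxy on a saturated chain carbon bound to a carbonyl carbon, with amino in place of hydroxy on a saturated chain carbon bound to a carbonyl carbon. The rest of the molecule stays as it is, so the natural starting point is compound 3 at 120 nM. Among the compounds with values here, with no measured example of this swap to draw on, the expectation in this assay is for no change beyond the scatter, in either direction. The expected step of a 1.1-fold higher number from compound 3 to compound 4 (0.03 log units; within the scatter) is therefore small. The range is kept wide because the data offer no direct guide. For compound 4 the estimated value is 130 nM, with an expected range from 40 nM to 450 nM.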

Compound 4, half-maximal inhibitory concentration: 330 nM
Compound 4: the middle estimate sits 2.5-fold (0.40 log units) below what was measured, and the stated range covers the measured number.
By their numbers in this assay, from the lowest: compound 3; then compounds 4 and 2 (each within the scatter of the next); then compound 1.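

Going by these compounds alone, this is the first pair in the set that differs in one place only, so a single change can now be read on its own: in this assay, amino in place of hydroxy on a saturated chain carbon bound to a carbonyl carbon gives a 2.8-fold higher number from compound 3 to compound 4 (0.44 log units; beyond the scatter) and counts as a modest step. The two groups have the same counts of heavy atoms, hydrogen-bond donors and hydrogen-bond acceptors, and neither carries a net charge, so a swap that leaves all of these counts unchanged still moves the number at this position. Nothing measured here explains why the number rises with this swap.

Going by these compounds, whether a methoxy group, a dimethylamino group or a carboxylic acid on this chain carbon would stay close to compound 3 or move further away remains open, as does the effect of a longer chain carrying the amino group. Also open, on these data alone, is whether the same swap would give a similar step on the core of compound 2, which carries hydroxy on the same chain.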